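Compound 3 to compound 4: a fluorine relocated

The source may report more compounds than this note shows. Statements on the series, on what has been measured and on what is new or still open speak of the compounds shown alone.

In an ADME assay on HepG2 2.2.15 cells (Homo sapiens) for cytotoxicity, read by MTT assay, with stated times of 48 h and 9 days (a higher number here means that more compound is tolerated, a lower number that less compound is tolerated), three compounds on a shared core have been measured. Compound 1 `COc1ccc2c(=O)c(/C=C/C(=O)Nc3cccc(Cl)c3)coc2c1` gives 1100000 nM, compound 2 `COc1ccc2c(=O)c(/C=C/C(=O)Nc3ccccc3)coc2c1` gives 523000 nM, and compound 3 `COc1ccc2c(=O)c(/C=C/C(=O)NCc3cccc(F)c3)coc2c1` gives 475000 nM. Compound 3 stands level with compound 2, as a 1.1-fold lower number from compound 2 to compound 3 (0.04 log units; within the scatter) shows. The larger gap in the set separates it from compound 1, with a 2.3-fold lower number from compound 1 to compound 3 (0.36 log units; beyond the scatter), and compound 2 lies at much the same distance, with a 2.1-fold lower number from compound 1 to compound 2 (0.32 log units; beyond the scatter).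

Compound 4 `COc1ccc2c(=O)c(/C=C/C(=O)NCc3ccccc3F)coc2c1` has the same atoms as compound 3, joined differently: 2-fluorophenyl in place of 3-fluorophenyl on a saturated chain carbon bound to an amide-type nitrogen. In words, it carries 2-fluorophenyl in place of 3-fluorophenyl on a saturated chain carbon bound to an amide-type nitrogen. For the measured compounds named here, no measured pair isolates this kind of change, so the evidence is indirect. The closest guide is the exchange of phenyl for 3-fluorobenzyl on the amide-type nitrogen, which gave a 1.1-fold lower number from compound 2 to compound 3 (0.04 log units; within the scatter). Even the replacement of the whole 3-chlorophenyl group by 3-fluorobenzyl gave only a 2.3-fold lower number from compound 1 to compound 3 (0.36 log units; beyond the scatter). A change that keeps every atom is therefore expected to produce no step beyond the scatter, and no direction can be favoured. The expected step is a 1.0-fold lower number from compound 3 to compound 4 (0.00 log units; within the scatter). For compound 4 the estimated value is 470000 nM, with an expected range from 250000 nM to 900000 nM.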

Compound 4, half-maximal cytotoxic concentration: 146000 nM
Beside the measured number, compound 4's estimate is 3.2-fold (0.51 log units) above it; measured number below the stated range.
By their numbers in this assay, from the lowest: compound 4; then compounds 3 and 2 (each within the scatter of the next); then compound 1.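

In this assay, for the compounds shown here, the exchange of 3-fluorophenyl for 2-fluorophenyl on a saturated chain carbon bound to an amide-type nitrogen leaves the atoms unchanged and still gives a 3.3-fold lower number from compound 3 to compound 4 (0.51 log units; beyond the scatter), so the number at this position depends on where the fluorine sits, which the earlier compounds could not show. It also changes how the benzyl groups compare with phenyl: 3-fluorobenzyl on the amide-type nitrogen gave a 1.1-fold lower number from compound 2 to compound 3 (0.04 log units; within the scatter), whereas 2-fluorobenzyl there gives a 3.6-fold lower number from compound 2 to compound 4 (0.55 log units; beyond the scatter), and in place of 3-chlorophenyl it gives a 7.5-fold lower number from compound 1 to compound 4 (0.88 log units; beyond the scatter), the widest step in the set. Nothing available accounts for this dependence on the fluorine's place.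

The compounds shown leave open whether 2-chlorobenzyl or 2-methoxybenzyl on the amide-type nitrogen would follow 2-fluorobenzyl or stay level with 3-fluorobenzyl. They also leave open whether the lower number would persist with 2-fluorophenyl directly on the amide-type nitrogen, or with a longer chain carrying that group.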